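Moving the Hydroxyl Group Around a Phenyl Ring

The source may hold more compounds than are shown below. What is called first, only, known or untested is meant among the compounds shown, and "the series" means these compounds.

In a functional assay on DU-145 cells (Homo sapiens) for cytotoxicity, read by ELISA, with a stated time of 2 days (a higher number here means a weaker inhibitor, a lower number a stronger inhibitor), compound 1 `Oc1cccc(-c2cc(-c3ccccc3)cc(-c3ccsc3)n2)c1` gives 11700 nM. Compound 2 `Oc1ccccc1-c1cc(-c2ccccc2)nc(-c2ccco2)c1` gives 4900 nM, the lower of the two numbers, and the gap between them lies beyond the usual scatter of repeat measurements. These two differ in more than one place, so their gap cannot be tied to a single change. Compound 3 `Oc1cccc(-c2cc(-c3ccccc3)nc(-c3ccco3)c2)c1` has the same atoms as compound 2, joined differently: 3-hydroxyphenyl in place of 2-hydroxyphenyl on an aromatic carbon, with 3-hydroxyphenyl in place of 2-hydroxyphenyl. Among the compounds with values here, no measured pair shows this change alone. Compound 1 also carries a 3-hydroxyphenyl group and gives 11700 nM, a loose hint toward a higher number in this assay. A small upward move is expected, and the estimated change is a 1.3-fold higher number from compound 2 to compound 3 (0.12 log units; within the scatter). For compound 3, the estimate is 6500 nM, with an expected range of 2200 nM to 19000 nM.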

Compound 3, half-maximal inhibitory concentration: 34900 nM
The estimate for compound 3 lay 5.4-fold (0.73 log units) below the measured number; the measured number lies above the stated range.
By their numbers in this assay, from the lowest: compound 2; then compound 1; then compound 3.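

Within the data shown here, compound 2 and compound 3 differ in one place only, so they give the first clean reading of this change, which the earlier pair could not give. Within this assay, 3-hydroxyphenyl in place of 2-hydroxyphenyl, on the aromatic carbon opposite the ring nitrogen, gives a 7.1-fold higher number from compound 2 to compound 3 (0.85 log units; beyond the scatter) and so a weaker inhibitor. The two groups have the same heavy atoms and the same counts of donors and acceptors, yet how they are joined moves the number beyond the scatter, and no measurement at hand explains this move.

On these data alone, whether the hydroxyl itself matters remains open, and a methoxy group or an amine on the same ring would test that. As far as these compounds go, it is also open whether the step would hold with another ring in place of the furan-2-yl group.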